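The source may hold more compounds than are shown below. What is called first, only, known or untested is meant among the compounds shown, and "the series" means these compounds.

Measured so far in an ADME assay on BCBL1 cells (Homo sapiens) for cytotoxicity, with a stated time of 7 days; a higher number here means that more compound is tolerated, a lower number that less compound is tolerated:
Compound 1 `COCCOc1nc(N)nc2c1ncn2/C=C1/CC1(CO)CO` gives > 20000 nM (a limit)
Compound 2 `CN(C)c1nc(N)nc2c1ncn2/C=C1/CC1(CO)CO` gives > 20000 nM (a limit)
Compound 3 `CC(C)Nc1nc(N)nc2c1ncn2/C=C1/CC1(CO)CO` gives > 20000 nM (a limit)

Compound 3 has no exact number, only a limit, and it sits with the other two compounds at the limit of > 20000 nM in this assay, at which 3 of the 3 values shown sit, on the scale of this test. The next compound, compound 4 `CCCNc1nc(N)nc2c1ncn2/C=C1/CC1(CO)CO`, differs from it by propyl in place of isopropyl on a nitrogen on an aromatic ring and so carries propyl in place of isopropyl on a nitrogen on an aromatic ring. The two have the same atoms, joined differently.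

Among the compounds with values here, three measured steps bear on this change: a step that the two limits leave unreadable from compound 2 to compound 3 and a step that the two limits leave unreadable from compound 1 to compound 3 and a step that the two limits leave unreadable from compound 1 to compound 2 as well. None of them has a size that can be read. Within the data shown here, still, no compound so far has left the limit, so no step beyond the scatter is expected in this assay and no direction can be given. The expected change is a number no higher from compound 3 to compound 4 (the limit leaves the size open) in the estimate made here. For compound 4 the estimated value is 20000 nM with an expected range from 10000 nM to 40000 nM and the assay will most likely report only a limit again.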

Compound 4, half-maximal cytotoxic concentration: > 20000 nM
Compound 4: no number, only a limit; the forecaster's own chance of this, stated with the estimate: 85%; the middle value lies on the limit itself.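

In this assay compound 4 gives > 20000 nM, which is a limit. Its steps from compound 1, compound 2 and compound 3 cannot be read. The compounds shown leave open whether any of the four differ in how much is tolerated, as all share one reading: the limit of > 20000 nM in this assay, at which 4 of the 4 values shown sit.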